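Carbamate variation on the selenocyanate aryl core

The source may report more compounds than this note shows. Statements on the series, on what has been measured and on what is new or still open speak of the compounds shown alone.

Measured compounds:
compound 1 `C=CCOC(=O)Nc1ccc([Se]C#N)cc1` — 50100 nM
compound 2 `N#C[Se]c1ccc(NC(=O)Oc2ccccc2)cc1` — 50200 nM

Both values come from a functional assay on HTB-54 cells (Homo sapiens) for cytotoxicity, read by MTT assay, with a stated time of 72 h; a higher number here means a weaker inhibitor of growth, a lower number a stronger inhibitor of growth. Compound 1 gives 50100 nM there, and compound 2 gives 50200 nM; the two numbers lie within the scatter of each other, so neither can be set above or below the other. Among the compounds with values here, the only measured step, a 1.0-fold higher number from compound 1 to compound 2 (0.00 log units; within the scatter), changes the group on the oxygen next to the carbonyl and leaves the number where it was.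

The unmeasured compound 3 `N#C[Se]c1ccc(NC(=O)OCc2ccccc2)cc1` differs from compound 1 as follows: phenyl in place of vinyl on a saturated chain carbon bound to an oxygen next to a carbonyl group. This again alters only the portion beyond the oxygen of the carbamate, the same region touched in the step from compound 1 to compound 2. Within the data shown here, that step was flat within the scatter, and it is the only comparison that bears on the present change. No step beyond the scatter is therefore expected in this assay for compound 3. The estimate for compound 3 is 50000 nM (range 25000 nM to 100000 nM), which corresponds to an expected step of a 1.0-fold lower number from compound 1 to compound 3 (0.00 log units; within the scatter). Two compounds form a thin basis, and a shift in either direction would not contradict them.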

Compound 3, concentration for total growth inhibition: 50800 nM
Estimate against measurement, compound 3: 1.0-fold (0.01 log units) below; low and high end bracket the measured number.
By their numbers in this assay, from the lowest: compounds 1, 2 and 3 (each within the scatter of the next).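

In this assay, the exchange at this place, with phenyl in place of vinyl on a saturated chain carbon bound to an oxygen next to a carbonyl group, gives a 1.0-fold higher number from compound 1 to compound 3 (0.01 log units; within the scatter), so the 6 heavy atoms and aromatic ring of phenyl are taken up here in place of the 2 heavy atoms and double bond of vinyl with no step beyond the scatter. The earlier step, a 1.0-fold higher number from compound 1 to compound 2 (0.00 log units; within the scatter), put phenyl on the oxygen itself, whereas this one keeps the saturated chain carbon and carries the ring on it, and the number again stays within the scatter, so the series now holds two different changes beyond the carbamate oxygen and neither moves this assay. No measured information is available to account for this flat result.

Still open, from the compounds shown here alone, is whether this place stays flat with a group that carries a hydrogen-bonding or charged function, such as an amine or a carboxylic acid, or with a longer chain ending in phenyl. The compounds shown also leave open whether any change to the carbamate itself, such as an amide in its place, or to the shared core would move the number in this assay.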